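The compounds below may be only part of what the source reports. "The series", "measured", "known", "first", "only" and "open" are said of these compounds alone.

Of the compounds shown here, three have so far been tested in an assay on isolated protein for inhibition of coagulation factor XII (Homo sapiens); on this read-out higher numbers stand for weaker inhibition and lower numbers for stronger inhibition. Compound 1 `O=C(Oc1ccccc1)c1cc2cc(CCl)ccc2oc1=O` gives only a limit there, > 50000 nM. Compound 2 `O=C(Nc1ccccc1)c1cc2ccccc2oc1=O` gives 42000 nM, and compound 3 `Cc1ccc2oc(=O)c(C(=O)Nc3ccccc3)cc2c1` gives 23000 nM, the lower of the two numbers, although the step of a 1.8-fold lower number from compound 2 to compound 3 (0.26 log units; within the scatter) is within the scatter. Compound 4 `Cc1ccc2oc(=O)c(C(=O)Nc3ccccc3Cl)cc2c1` differs from compound 3 by chloro in place of hydrogen on an aromatic carbon. Going by the values given here, the only measured step that bears on adding a small group to an aromatic carbon is a 1.8-fold lower number from compound 2 to compound 3 (0.26 log units; within the scatter), which did not move the number beyond the scatter, so no larger movement is expected here either. Compound 4 is therefore estimated at 16000 nM, within 5000 nM to 50000 nM, an expected step of a 1.4-fold lower number from compound 3 to compound 4 (0.16 log units; within the scatter) that would stay within the scatter.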

Compound 4, half-maximal inhibitory concentration: 30000 nM
The estimate for compound 4 lay 1.9-fold (0.27 log units) below the measured number, and the stated range covers the measured number.
By their numbers in this assay, from the lowest: compounds 3, 4 and 2 (each within the scatter of the next). At a limit, above all of these: compound 1.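

The step from phenyl to 2-chlorophenyl is the first change shown on this ring, and chloro ortho to a large group gives a 1.3-fold higher number from compound 3 to compound 4 (0.12 log units; within the scatter) in this assay. Chloro at this place therefore brings no change beyond the scatter, and no gain in inhibition can be read from it. The upper end of the read-out lies close, since compound 1 gives only a limit: the limit of > 50000 nM in this assay, at which 1 of the 4 values shown sits.

From the compounds shown here alone, whether an amine or a carboxylic acid at this place, or chloro elsewhere on this ring, would move the number beyond the scatter stays open.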